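The source may report more compounds than this note shows. Statements on the series, on what has been measured and on what is new or still open speak of the compounds shown alone.

In a functional assay on DU-145 cells (Homo sapiens) for antiproliferative activity, read by propidium iodide staining, with a stated time of 96 h (a lower number here means a stronger inhibitor, a higher number a weaker inhibitor), compound 1 `CC(O)(CSc1cccc(C(F)(F)F)c1)C(=O)Nc1ccc(S(F)(F)(F)(F)F)cc1` gives 26200 nM and compound 2 `CC(O)(CSc1ccccc1C(F)(F)F)C(=O)Nc1ccc(S(F)(F)(F)(F)F)cc1` gives 15800 nM; the change between them is 2-(trifluoromethyl)phenyl in place of 3-(trifluoromethyl)phenyl on a sulfur, and the step is a 1.7-fold lower number from compound 1 to compound 2 (0.22 log units; within the scatter). Compound 3 `CC(O)(CS(=O)(=O)c1cccc(C(F)(F)F)c1)C(=O)Nc1ccc(S(F)(F)(F)(F)F)cc1` gives 31900 nM in this assay; how its core differs from that of compound 1 is not broken down here. Compound 4 `CC(O)(CS(=O)(=O)c1ccccc1C(F)(F)F)C(=O)Nc1ccc(S(F)(F)(F)(F)F)cc1` carries the same kind of change relative to compound 3, (2-(trifluoromethyl)phenyl in place of 3-(trifluoromethyl)phenyl on a sulfonyl sulfur), but the place is not identical: in compound 1 the group sits on a sulfur, in compound 3 on a sulfonyl sulfur. Given that the only comparable step, a 1.7-fold lower number from compound 1 to compound 2 (0.22 log units; within the scatter), fell within the scatter, the expected step from compound 3 to compound 4 is of similar size, a 1.7-fold lower number from compound 3 to compound 4 (0.23 log units; within the scatter). Compound 4 is therefore estimated at 19000 nM in this assay, with a range from 9000 nM to 40000 nM.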

Compound 4, half-maximal inhibitory concentration: 29400 nM
Estimate against measurement, compound 4: 1.5-fold (0.19 log units) below, and the stated range covers the measured number.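

In this assay, 2-(trifluoromethyl)phenyl in place of 3-(trifluoromethyl)phenyl on a sulfonyl sulfur gives a 1.1-fold lower number from compound 3 to compound 4 (0.04 log units; within the scatter). Set beside the same change on a sulfur, the two steps do not differ by more than repeated measurements allow: the same change on two cores in this assay, a 1.7-fold lower number (0.22 log units; within the scatter) from compound 1 to compound 2 and a 1.1-fold lower number (0.04 log units; within the scatter) from compound 3 to compound 4, 1.5-fold (0.18 log units) apart, within the scatter of two such steps. The change therefore carries from one core to the other without a detectable difference, but since both steps lie within the scatter, neither core shows a real effect of the change, and two cores cannot show that this would hold on others.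

On these data alone, it remains open what a nitrile or a chlorine in place of the trifluoromethyl would do on either core. The same holds for an amine in place of the hydroxyl.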